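The source may hold more compounds than are shown below. What is called first, only, known or untested is meant among the compounds shown, and "the series" means these compounds.

Compound 2 `CC(=O)c1ccc(-c2cn3ccnc3c(-c3ccc4ncn(C5CCCCC5)c4c3)n2)cc1` carries a 4-acetylphenyl arm on the shared core. In a functional assay on MOLT-4 cells (Homo sapiens) for inhibition, read by sulforhodamine B assay, with a stated time of 48 h, tested at 10 uM (on this read-out higher numbers stand for more inhibition at the one concentration tested (going by the name of the read-out) and lower numbers for less inhibition), compound 2 gives 14.3%, the lower of the two numbers in hand. Among the compounds with values here, the only measured step leads to it: a number 44.4 percentage points lower from compound 1 to compound 2 (beyond the scatter), where compound 1 `O=Cc1ccc(-c2cn3ccnc3c(-c3ccc4ncn(C5CCCCC5)c4c3)n2)cc1` gives 58.7%. Compound 3 `Brc1ccc(-c2cn3ccnc3c(-c3ccc4ncn(C5CCCCC5)c4c3)n2)cc1` alters the same arm once more: bromo in place of acetyl on an aromatic carbon. Within the data shown here, no measured step follows this particular exchange, so the step from a hydrogen to a methyl on the carbonyl carbon only shows that changes at this place move the read-out strongly, not which way a bromo will move it. Because compound 2 gave 14.3% with the acetyl in place, and that group now leaves, a partial return toward the number of compound 1 seems as plausible as a further loss, so compound 3 is expected to show a number 13.7 percentage points higher from compound 2 to compound 3 (beyond the scatter). The estimate for compound 3 is 28%, with a range from 5% to 58%.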

Compound 3, a percentage reported as inhibition, at one concentration (the size of the read-out at that concentration, not a potency): 20.4%
Estimate against measurement, compound 3: 7.6 percentage points above; the range from low to high includes it.
By their numbers in this assay, from the lowest: compounds 2 and 3 (each within the scatter of the next); then compound 1.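

In this assay, replacing the acetyl with bromo makes no real difference: there is a number 6.1 percentage points higher from compound 2 to compound 3 (within the scatter), so a carbonyl-bearing arm and a bromine-bearing arm cannot be told apart at this place. The formyl arm stands apart from both, with a number 38.3 percentage points lower from compound 1 to compound 3 (beyond the scatter), and among these three compounds the higher number belongs to compound 1 alone, while compound 2 shows that having a carbonyl at this place does not by itself give that number. Nothing available explains why the formyl arm stands apart from the other two.

Going by these compounds, whether an amine, a carboxylic acid or a hydroxymethyl group at this place would stand with compound 1 or with the other two remains open. Also open, on these data alone, is whether any group other than formyl can reach the number of compound 1.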